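Halogen swap at the pyridine: from chloro to bromo

The source may hold more compounds than are shown below. What is called first, only, known or untested is meant among the compounds shown, and "the series" means these compounds.

Measured compounds:
Compound 1, `Fc1ncc(OC[C@@H]2CCN2)cc1-c1cccnc1`: in an assay on membranes from brain with Neuronal acetylcholine receptor; alpha4/beta2 (Rattus norvegicus) as the target (on this read-out higher numbers stand for weaker inhibition and lower numbers for stronger inhibition), compound 1 gives 0.066 nM.
Compound 2, `Clc1ncc(OC[C@@H]2CCN2)cc1-c1cccnc1`: in this assay compound 2 gives 0.0081 nM.

Of the two numbers available, compound 2 has the lowest, and the nearest is compound 1, which gives a number higher by an 8.1-fold lower number from compound 1 to compound 2 (0.91 log units; beyond the scatter). That single step, chloro in place of fluoro on an aromatic carbon, is the only one bearing on the next change, and it lies beyond the usual scatter.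

Compound 3, `Brc1ncc(OC[C@@H]2CCN2)cc1-c1cccnc1`, is not yet measured. It differs from compound 2 by bromo in place of chloro on an aromatic carbon. This is the next halogen in the same position. One step is thin evidence, and it is unclear whether the gain seen from fluoro to chloro continues. The expected outcome is a further small step, likely within the scatter or only a little beyond it, toward a lower number.

Compound 3 is estimated at 0.005 nM, with a range from 0.0015 nM to 0.02 nM, which means an expected step of a 1.6-fold lower number from compound 2 to compound 3 (0.21 log units; within the scatter).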

Compound 3, inhibition constant: 0.0066 nM
The estimate for compound 3 lay 1.3-fold (0.12 log units) below the measured number; measured number inside the range.
By their numbers in this assay, from the lowest: compounds 3 and 2 (each within the scatter of the next); then compound 1.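

On the aromatic carbon next to the ring nitrogen, this assay shows a 1.2-fold lower number from compound 2 to compound 3 (0.09 log units; within the scatter), so the bromo and chloro compounds cannot be told apart and the improvement seen on leaving fluoro does not clearly continue down the halogens. Bromo in place of fluoro gives a 10-fold lower number from compound 1 to compound 3 (1.00 log units; beyond the scatter) and stands beside an 8.1-fold lower number from compound 1 to compound 2 (0.91 log units; beyond the scatter) as a second step beyond the scatter, so among these three compounds the fluoro compound alone stands apart, while chloro and bromo form a single level with very low numbers. Nothing here offers an explanation for that difference between fluoro and the two larger halogens.

The compounds shown leave open whether this level is special to chloro and bromo or would also be reached by a different kind of group at the same carbon, such as iodo, methyl or a nitrile. They also leave open whether chloro and bromo, so alike in this binding measurement, would stay alike at other receptors or in a functional test.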